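The source may report more compounds than this note shows. Statements on the series, on what has been measured and on what is new or still open speak of the compounds shown alone.

For the measured compounds named here, the three compounds measured so far share one core and differ in two places. Compound 1 `C=CCn1c(=O)/c(=C\c2cccc(Cl)c2)[nH]c(=O)/c1=C\c1ccccc1OC` gives 1200 nM in a functional assay on U-937 cells (Homo sapiens) for cytotoxicity, read by CCK-8 assay, with a stated time of 72 h; on this read-out higher numbers stand for weaker inhibition and lower numbers for stronger inhibition. Compound 2 `COc1ccccc1/C=c1/[nH]c(=O)/c(=C\c2ccccc2OC)n(C)c1=O` gives 1500 nM in this assay. Compound 3 `C=CCn1c(=O)/c(=C\c2ccccc2OC)[nH]c(=O)/c1=C\c1ccccc1OC` gives 5100 nM in this assay, the highest number of the three, set apart from both companions by steps beyond the scatter: a 4.3-fold higher number from compound 1 to compound 3 (0.63 log units; beyond the scatter) and a 3.4-fold higher number from compound 2 to compound 3 (0.53 log units; beyond the scatter).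

Compound 4 `C=CCn1c(=O)/c(=C\c2cc(F)ccc2C)[nH]c(=O)/c1=C\c1ccccc1OC` is not yet measured. It differs from compound 3 in one place: 5-fluoro-2-methylphenyl in place of 2-methoxyphenyl on a double-bonded chain carbon bound to an aromatic carbon. Going by the values given here, of the two measured steps, only the one from compound 1 to compound 3 touches the same place, and there the exchange of a halogenated phenyl for the methoxy-bearing phenyl raised the number by a 4.3-fold higher number from compound 1 to compound 3 (0.63 log units; beyond the scatter). The step from compound 2 to compound 3 concerns the saturated chain carbon bound to the aromatic nitrogen and does not bear on this change. Since compound 4 reintroduces a halogen-bearing phenyl at that position, though a different one, a modest step toward a lower number is expected in this assay, estimated as a 2.6-fold lower number from compound 3 to compound 4 (0.41 log units; beyond the scatter). Compound 4 is therefore expected to give about 2000 nM, within a range from 700 nM to 6000 nM.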

Compound 4, half-maximal inhibitory concentration: 1000 nM
Beside the measured number, compound 4's estimate is 2.0-fold (0.30 log units) above it; the range from low to high includes it.
By their numbers in this assay, from the lowest: compounds 4, 1 and 2 (each within the scatter of the next); then compound 3.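

In this assay, the exchange of 2-methoxyphenyl for 5-fluoro-2-methylphenyl gives a 5.1-fold lower number from compound 3 to compound 4 (0.71 log units; beyond the scatter), so the lower number at this place on a double-bonded chain carbon bound to an aromatic carbon is no longer tied to the 3-chlorophenyl group of compound 1 alone. The two groups that replace 2-methoxyphenyl cannot be told apart here, with a 1.2-fold lower number from compound 1 to compound 4 (0.08 log units; within the scatter), even though they carry different halogens and only one of them has a methyl group; among these three compounds, which share the same group at the other varied place, it is compound 3 with its 2-methoxyphenyl that stands apart, and none goes against this. No measurement at hand explains why this exchange moves the number.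

The compounds shown do not separate the contributions of the fluorine, the methyl group and the departure of the methoxy group, since all three change together between compound 3 and compound 4. They also leave open whether an amine or a carboxylic acid on this phenyl ring would be tolerated in this assay, and whether the methyl group on the nitrogen of compound 2 would behave the same way alongside 5-fluoro-2-methylphenyl.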